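The compounds below may be only part of what the source reports. "The series", "measured", "known", "first", "only" and "open" are said of these compounds alone.

In a functional assay on MCF7 cells (Homo sapiens) for antiproliferative activity, read by CellTiter-Glo, with a stated time of 5 days (a lower number here means a stronger inhibitor, a higher number a weaker inhibitor), compound 1 `CC/C(=C(/c1ccc(/C=C/C(=O)O)cc1)c1ccc(-c2cncs2)cc1)c1ccccc1` gives 31 nM, compound 2 `CC/C(=C(/c1ccc(/C=C/C(=O)O)cc1)c1ccc(-c2nccs2)cc1)c1ccccc1` gives 290 nM, and compound 3 `CC/C(=C(/c1ccc(/C=C/C(=O)O)cc1)c1ccc(-c2cc[nH]n2)cc1)c1ccccc1` gives 440 nM. These three compounds differ only in one five-membered aromatic ring. Compound 3 lies within the scatter of compound 2, with a 1.5-fold higher number from compound 2 to compound 3 (0.18 log units; within the scatter). Both stand well apart from compound 1, as seen in a 9.4-fold higher number from compound 1 to compound 2 (0.97 log units; beyond the scatter) and a 14-fold higher number from compound 1 to compound 3 (1.15 log units; beyond the scatter).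

Compound 4 `CC/C(=C(/c1ccc(/C=C/C(=O)O)cc1)c1ccc(-c2cnn(C)c2)cc1)c1ccccc1` changes that same ring: 1-methyl-1H-pyrazol-4-yl in place of 1H-pyrazol-3-yl on an aromatic carbon. It carries 1-methyl-1H-pyrazol-4-yl in place of 1H-pyrazol-3-yl on an aromatic carbon, para to a large group. Among the compounds with values here, no measured step covers this exchange directly, so the evidence is indirect and comes from three ring exchanges only. One of them, a 14-fold higher number from compound 1 to compound 3 (1.15 log units; beyond the scatter), is large, while another, a 1.5-fold higher number from compound 2 to compound 3 (0.18 log units; within the scatter), stays within the scatter. A ring exchange at this place can therefore matter a great deal or hardly at all. With compound 3 at 440 nM and compound 1 at 31 nM, a modest move toward a lower number seems the likelier outcome, though the uncertainty is wide. The step expected in this assay is a 4.4-fold lower number from compound 3 to compound 4 (0.64 log units; beyond the scatter). For compound 4 the estimated value is 100 nM, with an expected range of 25 nM to 400 nM.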

Compound 4, half-maximal inhibitory concentration: 80 nM
Compound 4: middle estimate off by 1.3-fold (0.10 log units), on the high side, within the range that was stated.
By their numbers in this assay, from the lowest: compound 1; then compound 4; then compounds 2 and 3 (each within the scatter of the next).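

In this assay, a pyrazole at this place on the aromatic ring need not sit at the weak end of the series, as a 5.5-fold lower number from compound 3 to compound 4 (0.74 log units; beyond the scatter) shows for 1-methyl-1H-pyrazol-4-yl against 1H-pyrazol-3-yl. The new group also improves on 1,3-thiazol-2-yl, with a 3.6-fold lower number from compound 2 to compound 4 (0.56 log units; beyond the scatter), but it does not match 1,3-thiazol-5-yl, with a 2.6-fold higher number from compound 1 to compound 4 (0.41 log units; beyond the scatter), so among these compounds the ring type alone does not fix the result: the two thiazoles lie apart, and so do the two pyrazoles. No measured evidence accounts for these differences, and the numbers themselves give no cause for them.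

This one exchange alters both the methyl group and the ring's point of attachment, so the compounds shown cannot say which of the two matters; an unmethylated 1H-pyrazol-4-yl or a 1-methyl-1H-pyrazol-3-yl would separate them. Also open, from the compounds shown here alone, is whether an ethyl group in place of that methyl, or an amine on the five-membered ring, would bring the number closer to that of compound 1.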